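Exchanging One Five-Membered Ring for Another on the Core

A few compounds are considered here, and "the series" means these few. Any claim that something is new, unique, unknown or untested is made for them only; others in the source may bear on it.

Compound 3 `O=C(O)CC(c1ccc(OCC2COc3ccc(Cl)cc3O2)cc1)c1cnco1` carries a 1,3-oxazol-5-yl group on a saturated chain carbon bound to an aromatic carbon and a saturated chain carbon. For the measured compounds named here, in a functional assay on HEK293 cells for agonist activity at Free fatty acid receptor 1 (Homo sapiens), read by fluorescence and calcium flux, with a stated time of 10 min (on this read-out higher numbers stand for larger maximal responses and lower numbers for smaller maximal responses), compound 3 gives 63%, the second highest of the three numbers measured so far. Its nearest neighbour is compound 2 `CCOC(CC(=O)O)c1ccc(OCC2COc3ccc(Cl)cc3O2)cc1`, which gives 46% in this assay; the step between them is a number 17 percentage points higher from compound 2 to compound 3 (beyond the scatter). Furthest away is compound 1 `CC#CC(CC(=O)O)c1ccc(OCC2COc3ccc(Cl)cc3O2)cc1`, which reaches 104% in this assay; here the step is a number 41 percentage points lower from compound 1 to compound 3 (beyond the scatter), and for comparison a number 58 percentage points lower from compound 1 to compound 2 (beyond the scatter).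

Compound 4 `Cn1ccnc1C(CC(=O)O)c1ccc(OCC2COc3ccc(Cl)cc3O2)cc1` differs from compound 3 in one place: 1-methyl-1H-imidazol-2-yl in place of 1,3-oxazol-5-yl on a saturated chain carbon bound to an aromatic carbon and a saturated chain carbon. Going by the values given here, both groups are five-membered aromatic rings with two hetero atoms and two hydrogen-bond acceptors, so in counted terms this is a smaller change than the earlier steps, which replaced prop-1-yn-1-yl by ethoxy or by the oxazole ring. Among the compounds with values here, those steps show that this place matters for the maximal response, but no measured pair exchanges one small heteroaromatic ring for another, and the only ring-involving step, a number 17 percentage points higher from compound 2 to compound 3 (beyond the scatter), was modest. The expected step is therefore small, a number 3 percentage points lower from compound 3 to compound 4 (within the scatter), with wide uncertainty. Compound 4 is estimated to give 60% in this assay, between 35% and 90%.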

Compound 4, largest response reached (Emax), in percent of the reference or control that the assay uses: 68%
The estimate for compound 4 lay 8 percentage points below the measured number; low and high end bracket the measured number.
By their numbers in this assay, from the lowest: compound 2; then compounds 3 and 4 (each within the scatter of the next); then compound 1.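

With 1-methyl-1H-imidazol-2-yl in place of 1,3-oxazol-5-yl on this saturated chain carbon, the data now include a direct exchange of one five-membered aromatic ring for another, and a number 5 percentage points higher from compound 3 to compound 4 (within the scatter) in this assay shows that this exchange gives no difference that can be told from the scatter, even though the entering ring has one more heavy atom and a different set of hetero atoms. The ring result also holds up against the other two groups at this place, with a number 22 percentage points higher from compound 2 to compound 4 (beyond the scatter) on the ethoxy side and a number 36 percentage points lower from compound 1 to compound 4 (beyond the scatter) on the prop-1-yn-1-yl side, so compounds 3 and 4 both sit beyond the scatter from compound 1 and from compound 2. Nothing available here speaks to what lies behind these numbers.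

The compounds shown leave open whether the methyl group or the ring atoms matter more on their own, which a 1H-imidazol-2-yl ring without the methyl could help to separate. They also leave open whether a six-membered ring such as pyridin-2-yl, or a shorter alkyne such as ethynyl, would come closer to the response of compound 1.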